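A Furan-to-Benzyl Swap on the Amine Chain

The compounds below may be only part of what the source reports. "The series", "measured", "known", "first", "only" and "open" are said of these compounds alone.

Measured compounds:
compound 1, `COc1cccc(CNCCCNc2ccnc3cc(Cc4cccc(C(F)(F)F)c4)ccc23)c1O`: 23 10^-6 cm/s
compound 2, `Fc1ccc(Cc2ccc3c(NCCCNCc4ccco4)ccnc3c2)c(Cl)c1`: 23 10^-6 cm/s
compound 3, `COc1ccc(Oc2ccc3c(NCCCNCc4ccco4)ccnc3c2)cc1`: 317 10^-6 cm/s

In an ADME assay for permeability, using PAMPA, with a stated time of 30 min, at pH 7.4 (a higher number here means that the compound crosses the layer faster, a lower number that the compound crosses the layer more slowly), compound 2 gives 23 10^-6 cm/s, level with compound 1 at the digits shown, and the two share the lowest numbers of the three. Compound 3 stands furthest away, as the step of a 14-fold higher number from compound 2 to compound 3 (1.14 log units; beyond the scatter) shows. That step alters the group on the aromatic carbon of the shared core, not the amine arm.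

Compound 4, `COc1cccc(CNCCCNc2ccnc3cc(Cc4ccc(F)cc4Cl)ccc23)c1O`, has not yet been measured. It keeps the aromatic substituent of compound 2 and changes the amine arm: 2-hydroxy-3-methoxyphenyl in place of furan-2-yl on a saturated chain carbon bound to an amine nitrogen. For the measured compounds named here, no measured step touches this exact change. Compound 1, which already carries the 2-hydroxy-3-methoxybenzyl arm, gives a number level with compound 2, so the arm alone does not appear to move the read-out here. The step of no change at the digits printed from compound 2 to compound 4 (within the scatter) is therefore expected to stay within the usual scatter. Compound 4 is estimated at 23 10^-6 cm/s, with a range from 10 10^-6 cm/s to 50 10^-6 cm/s.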

Compound 4, apparent permeability: 23 10^-6 cm/s
Compound 4: middle estimate and measured number agree at the digits printed, and the stated range covers the measured number.
By their numbers in this assay, from the lowest: compounds 1, 2 and 4 (each within the scatter of the next); then compound 3.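

With the 2-chloro-4-fluorobenzyl group held fixed, the amine arm can now be read directly in this assay: 2-hydroxy-3-methoxyphenyl, which brings a hydrogen-bond donor that furan-2-yl lacks, gives no change at the digits printed from compound 2 to compound 4 (within the scatter) at this saturated chain carbon bound to an amine nitrogen. With the 2-hydroxy-3-methoxybenzyl arm held fixed instead, 2-chloro-4-fluorophenyl in place of 3-(trifluoromethyl)phenyl gives no change at the digits printed from compound 1 to compound 4 (within the scatter) on its chain carbon, so among the compounds shown only the 4-methoxyphenoxy group of compound 3 sets a number apart. No measurement at hand offers a reason for these results.

Still open, going by these compounds, is how the 2-hydroxy-3-methoxybenzyl arm reads alongside the 4-methoxyphenoxy group of compound 3. Also open, on these data alone, is whether an arm ending in a carboxylic acid or a dimethylamino group would shift the number.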